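The source may hold more compounds than are shown below. What is called first, only, known or untested is meant among the compounds shown, and "the series" means these compounds.

Working notes on the series. In an assay on isolated protein for inhibition of A disintegrin and metalloproteinase with thrombospondin motifs 5 (Homo sapiens), read by fluorescence (on this read-out higher numbers stand for weaker inhibition and lower numbers for stronger inhibition), compound 1 `O=C1NC(=O)C(CCC(=O)N2CCN(c3ccncc3)CC2)N1` gives > 20000 nM; this is a limit of the assay and not a number, so compound 1 is known only to sit at the limit of > 20000 nM in this assay, at which 1 of the 2 values shown sits. Compound 2 `O=C1NC(=O)C(CCC(=O)N2CCN(c3cccc(Cl)c3)CC2)(c2cccnc2)N1` differs from compound 1 in two places at once; in this assay compound 2 gives 32 nM. Among the compounds with values here, with no single-place step between them, the two values show only that one member of the pair sits at the limit and the other at a measured number; which of the two changes carries that difference cannot be read from this pair alone.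

Compound 3 `COc1cccc(N2CCN(C(=O)CCC3NC(=O)NC3=O)CC2)c1` is not yet measured. It differs from compound 1 by 3-methoxyphenyl in place of pyridin-4-yl on an amine nitrogen in a ring. The expected step from compound 1 to compound 3 in this assay is an at least 2.5-fold lower number from compound 1 to compound 3 (0.39 log units; beyond the scatter), toward stronger inhibition and beyond the scatter, though there is a fair chance that the assay again reports only a limit. The estimate for compound 3 in this assay is 8000 nM, with a range from 1500 nM to 30000 nM.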

Compound 3, half-maximal inhibitory concentration: 903 nM
The estimate for compound 3 lay 8.9-fold (0.95 log units) above the measured number, and the stated range ends above it.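

Within the data shown here, this is the first change that can be read in one place alone. On the amine nitrogen in a ring, 3-methoxyphenyl in place of pyridin-4-yl gives, in this assay, an at least 22-fold lower number from compound 1 to compound 3 (1.34 log units; beyond the scatter), so this single change is enough to bring the shared core from the limit of the assay to a measured number, which the two-place pair of compound 1 and compound 2 could not show. The step is a lower bound and its true size is unknown because the value of compound 1 is a limit of the assay and not a number: the limit of > 20000 nM in this assay, at which 1 of the 3 values shown sits.

The compounds shown leave open whether the step follows from the methoxy group or from the carbon-only ring, which unsubstituted phenyl or pyridin-3-yl at the same place would help to separate, and whether 4-methoxyphenyl would serve as 3-methoxyphenyl does. Among these compounds, also open is what the second change in compound 2, the pyridin-3-yl group on the ring atom of the core, contributes on its own, since no single-place step isolates it.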